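This account rests on a few compounds, and the source may have more. Where it says the series, first, only, none or still open, it means among the compounds named here.

In an ADME assay on microsomes from liver (Homo sapiens) for metabolic stability (a higher number here means that the compound lasts longer, a lower number that the compound disappears faster), compound 1 `COc1cc(OCc2csc(-c3ccc(C(F)(F)F)cc3)n2)c2cc(-c3cn4nc(OC)sc4n3)oc2c1` reports > 2 h, which is a limit of the assay and not a number. Within the data shown here, compound 2 `COc1cc(OCc2csc(-c3ccc(C(C)(C)O)cc3)n2)c2cc(-c3cn4nc(OC)sc4n3)oc2c1` gives 1.83 h, the only actual number so far. Among the measured compounds shown here, the one measured step, an at least 1.0-fold lower number from compound 1 to compound 2 (0.03 log units; that floor lies within the scatter), lies within the scatter and rests on (the limit of > 2 h in this assay, at which 1 of the 2 values shown sits). Compound 3 `CNC(=O)c1ccc(-c2nc(COc3cc(OC)cc4oc(-c5cn6nc(OC)sc6n5)cc34)cs2)cc1` keeps the shared core and changes a single group: methylcarbamoyl in place of 1-hydroxy-1-methylethyl on an aromatic carbon. Here methylcarbamoyl stands in place of 1-hydroxy-1-methylethyl on an aromatic carbon, para to a large group. For the measured compounds named here, only the step to compound 2 an at least 1.0-fold lower number from compound 1 to compound 2 (0.03 log units; that floor lies within the scatter) bears on this change, and it involves a different exchange, so it is a weak guide. No change beyond the scatter is therefore expected in this assay. The expected step is a 1.1-fold lower number from compound 2 to compound 3 (0.06 log units; within the scatter). For compound 3 the estimated half-life is 1.6 h, with an expected range of 0.8 h to 2.5 h.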

Compound 3, half-life: 0.983 h
The estimate for compound 3 lay 1.6-fold (0.21 log units) above the measured number, within the range that was stated.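

Among these compounds, at this position, on an aromatic carbon para to a large group, this assay now gives a step between two real numbers for the first time: a 1.9-fold lower number from compound 2 to compound 3 (0.27 log units; within the scatter). On that step methylcarbamoyl and 1-hydroxy-1-methylethyl cannot be told apart, although the earlier step offered no reading of this exchange. Against trifluoromethyl the comparison gives an at least 2.0-fold lower number from compound 1 to compound 3 (0.30 log units; that floor lies within the scatter), which is only a floor, so its true size stays unknown: the limit of > 2 h in this assay, at which 1 of the 3 values shown sits.

The compounds shown leave open whether any group at this position moves the half-life beyond the scatter. A carboxylic acid, an amine or a nitrile here, or a longer chain in place of the methyl of methylcarbamoyl, would bear on that question.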